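Working notes toward compound 4 in the cytotoxicity series

The compounds below may be only part of what the source reports. "The series", "measured", "known", "first", "only" and "open" are said of these compounds alone.

Measured so far:
Compound 1 `COc1ccc2c(c1)c(/C=N/O)cn2Cc1cn([C@@H]2O[C@H](COC(C)=O)[C@@H](OC(C)=O)[C@H](OC(C)=O)[C@H]2OC(C)=O)nn1`; in a functional assay on HeLa cells (Homo sapiens) for cytotoxicity, read by sulforhodamine B assay, with a stated time of 48 h (a lower number here means a stronger inhibitor, a higher number a weaker inhibitor), compound 1 gives only a limit, > 200000 nM.
Compound 2 `CC(=O)OC[C@H]1O[C@@H](n2cc(CN3C(=O)/C(=C\C=C\c4ccccc4)c4ccccc43)nn2)[C@H](OC(C)=O)[C@@H](OC(C)=O)[C@@H]1OC(C)=O`; in this assay compound 2 gives 98100 nM.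
Compound 3 `CC(=O)OC[C@H]1O[C@@H](n2cc(CN3C(=O)/C(=C/C=C/c4ccccc4)c4ccccc43)nn2)[C@H](OC(C)=O)[C@@H](OC(C)=O)[C@@H]1OC(C)=O`; in this assay compound 3 gives only a limit, > 100000 nM.

For the measured compounds named here, compound 2 therefore stands as the only compound with a number in this assay; the other two values are limits of the assay, see the limit of > 100000 nM in this assay, at which 1 of the 3 values shown sits, and (the limit of > 200000 nM in this assay, at which 1 of the 3 values shown sits). Going by the values given here, the single measured step with a number on one side is an at least 1.0-fold higher number from compound 2 to compound 3 (0.00 log units; that floor lies within the scatter), and it rests on (the fact that compounds 2 and 3 differ only in the configuration as drawn), a change of drawn configuration alone.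

Compound 4 `CC(=O)OC[C@H]1O[C@@H](n2cc(CN3C(=O)/C(=C\c4ccco4)c4ccccc43)nn2)[C@H](OC(C)=O)[C@@H](OC(C)=O)[C@@H]1OC(C)=O` differs from compound 2 by furan-2-yl in place of 2-phenylethenyl on a double-bonded chain carbon bound to a double-bonded ring carbon. Among the compounds with values here, no measured step exchanges this group, so the measured steps bear on it only indirectly: all three compounds sit at or near the weak end of this assay, and compound 3 shows that altering the chain beside the shared core did not bring a stronger number. The step of a 1.0-fold higher number from compound 2 to compound 4 (0.01 log units; within the scatter) is expected to stay within the scatter, with a real chance that compound 4 returns only a limit. Compound 4 is expected at 100000 nM, with a range from 40000 nM to 250000 nM.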

Compound 4, half-maximal inhibitory concentration: > 100000 nM
Compound 4 was reported as a limit; the forecaster's own chance of this, stated with the estimate: 50%; the middle value sits exactly at the limit.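

In this assay, furan-2-yl in place of 2-phenylethenyl on a double-bonded chain carbon bound to a double-bonded ring carbon gives an at least 1.0-fold higher number from compound 2 to compound 4 (0.00 log units; that floor lies within the scatter). Unlike the step from compound 2 to compound 3, this one changes the group itself and not only the drawn configuration, yet it also gives no number stronger than that of compound 2. Compound 4 gives only a limit, > 100000 nM, and so joins compound 3 at the same limit: the limit of > 100000 nM in this assay, at which 2 of the 4 values shown sit.

The change removes a double bond outside aromatic rings and replaces a carbon-only six-membered aromatic ring with a five-membered one holding oxygen, so the compounds shown cannot separate these parts, and the true size of the step stays unknown. From the compounds shown here alone, whether an amine or a carboxylic acid at this place would give a clearly stronger number also remains open.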